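The source may hold more compounds than are shown below. What is called first, only, known or untested is meant among the compounds shown, and "the series" means these compounds.

Measured compounds:
Compound 1, `N#Cc1ccc(CSc2ncnc3c2ncn3[C@@H]2O[C@H](CO)[C@@H](O)[C@H]2O)cc1`, gives 4.57 nM in an assay on isolated protein for inhibition of Equilibrative nucleoside transporter 1 (Homo sapiens); on this read-out lower numbers stand for stronger inhibition and higher numbers for weaker inhibition.
Compound 2, `O=[N+]([O-])c1ccccc1CSc1ncnc2c1ncn2[C@@H]1O[C@H](CO)[C@@H](O)[C@H]1O`, gives 115 nM in this assay.

For the measured compounds named here, compound 2 stands with the highest number of the two measured compounds, meaning it is the weaker inhibitor of the pair; the one step that connects it to a measured compound is a 25-fold higher number from compound 1 to compound 2 (1.40 log units; beyond the scatter), and that step is large.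

Compound 3, `Cc1ccc(CSc2ncnc3c2ncn3[C@@H]2O[C@H](CO)[C@@H](O)[C@H]2O)cc1`, has not yet been measured. It arises from compound 2 by the change (4-methylphenyl in place of 2-nitrophenyl on a saturated chain carbon bound to a sulfur). Going by the values given here, the only measured step that bears on this change is the one just described, in which a 2-nitrophenyl replaced a 4-cyanophenyl and the number rose sharply from compound 1 to compound 2. Compound 3 carries a 4-methylphenyl, which shares with compound 1 a phenyl bearing one group named with the same position number, so a return toward the number of compound 1 is expected rather than a stay at the level of compound 2, though the size of that return is uncertain because the two measured compounds differ in more than one respect within the group exchanged. The expected step is therefore a drop, a 9.6-fold lower number from compound 2 to compound 3 (0.98 log units; beyond the scatter). Compound 3 is expected to give 12 nM, in the range from 3 nM to 50 nM.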

Compound 3, inhibition constant: 15.1 nM
Estimate against measurement, compound 3: 1.3-fold (0.10 log units) below, within the range that was stated.
By their numbers in this assay, from the lowest: compound 1; then compound 3; then compound 2.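

In this assay, putting 4-methylphenyl in place of 2-nitrophenyl on the saturated chain carbon bound to the sulfur gives a 7.6-fold lower number from compound 2 to compound 3 (0.88 log units; beyond the scatter), which shows that a group with only carbon among its heavy atoms, and no hydrogen-bond acceptors by the count, can still give a much lower number than the 2-nitrophenyl group. For the compounds shown here, the new compound also provides the first comparison in which a single group on the aromatic ring changes while the rest of the molecule stays the same: methyl in place of cyano on an aromatic carbon gives a 3.3-fold higher number from compound 1 to compound 3 (0.52 log units; beyond the scatter), so the choice of that small group alone moves the number beyond the scatter. Nothing available explains either step.

The 2-nitrophenyl and 4-methylphenyl groups differ both in the group they carry and in the position number of that group, so the compounds shown cannot divide the larger step between those two differences. They also leave open how the number would respond to a plain phenyl ring without an added group, or to a methoxy group or an amine in place of the methyl.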